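The source may report more compounds than this note shows. Statements on the series, on what has been measured and on what is new or still open speak of the compounds shown alone.

Of the compounds shown here, three of this set have been tested in an assay on CHO cells for agonist activity at transient receptor potential cation channel subfamily V member 1 (Homo sapiens); on this read-out higher numbers stand for an effect only at larger amounts of compound and lower numbers for an effect already at smaller amounts. Compound 1 `CC1CCN(c2nc(C(F)(F)F)ccc2CNC(=O)Nc2cccc3ccc(=O)[nH]c23)CC1` and compound 2 `CC1CCN(c2nc(C(F)(F)F)ccc2CNC(=O)Nc2cccc3cc[nH]c(=O)c23)CC1` gave no activity reading: compound 1 was reported as "not active" (no number reported), and compound 2 likewise as "not active" (no number reported), so neither of them contributes a number that could be compared. Among the measured compounds shown here, compound 3 `CCCN(CCC)c1nc(C(F)(F)F)ccc1CNC(=O)Nc1cccc2c(=O)[nH]ccc12` is therefore the only compound with a measured value, and in this assay compound 3 gives 2.79 nM. It stands alone among the numbers shown, and no step between two measured compounds is available to say how strongly this series responds to a change at any one position.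

Compound 4 `CC(C)c1cccc(-c2nc(C(F)(F)F)ccc2CNC(=O)Nc2cccc3c(=O)[nH]ccc23)c1` shares the whole core with compound 3 and differs from it in a single place: 3-isopropylphenyl in place of dipropylamino on an aromatic carbon. A substituent without a ring thus gives way to a substituent carrying a six-membered aromatic ring of carbon only, while the rest of the molecule, including the urea and the bicyclic part at the other end, stays as it is.

For the measured compounds named here, with no measured step to lean on, the expectation for compound 4 can only be cautious. A change of this kind at the same position is expected to move the value in the weaker direction, by a step of a 2.9-fold higher number from compound 3 to compound 4 (0.46 log units; beyond the scatter), which is beyond the usual scatter but not large. Compound 4 is accordingly estimated at 8 nM, with a range from 1.5 nM to 50 nM that allows for the possibility that the activity is in fact kept in full.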

Compound 4, half-maximal effective concentration: 3.07 nM
Compound 4: middle estimate off by 2.6-fold (0.42 log units), on the high side, within the range that was stated.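

In this assay the exchange gives a 1.1-fold higher number from compound 3 to compound 4 (0.04 log units; within the scatter), so the two compounds cannot be told apart on this read-out. Among the compounds shown here, this is the first measured step, and it shows that the aromatic carbon next to the ring nitrogen can carry either dipropylamino or 3-isopropylphenyl with no measurable loss: a group without a ring and one with a six-membered aromatic ring of carbon only give the same level of effect, even though the nitrogen of the leaving group has no counterpart in the entering one. No measurement is available that would explain why these two different groups match.

For the compounds shown here, one step shows only that these two large groups give matching values, so it remains open whether a much smaller group at this carbon, such as methyl, would do the same, or whether a ring amine such as morpholine would. On these data alone, it also remains open how much the isopropyl group itself contributes, which a plain phenyl group at the same carbon would help to answer.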